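Adding a bromo group to compound 2

The source may hold more compounds than are shown below. What is called first, only, known or untested is meant among the compounds shown, and "the series" means these compounds.

Compound 1 `COc1ccc([C@@H]2CC(=O)c3cc(CC=C(C)C)c(OC)cc3O2)cc1` gives 65%
Compound 2 `COc1cc2c(cc1CC=C(C)C)C(=O)C[C@@H](c1ccc(Oc3ccccc3)cc1)O2` gives 69%

In a functional assay on MCF7 cells (Homo sapiens) for inhibition, read by sulforhodamine B assay, with a stated time of 48 h, tested at 50 uM (a lower number here means less inhibition of growth, a higher number more inhibition of growth at the concentration tested), compound 2 gives 69% and so stands within the scatter of compound 1. Compound 3 `COc1cc2c(cc1CC=C(C)C)C(=O)C[C@@H](c1ccc(Oc3ccc(Br)cc3)cc1)O2` has bromo in place of hydrogen on an aromatic carbon which turns phenoxy into 4-bromophenoxy. For the measured compounds named here, the only measured step is a number 4 percentage points higher from compound 1 to compound 2 (within the scatter) and it involves a different change, so it offers weak guidance. No shift beyond the scatter is therefore expected in this assay for compound 3. The expected step is a number 1 percentage points higher from compound 2 to compound 3 (within the scatter) on this reasoning. Compound 3 is estimated at 70% with an expected range from 55% to 85% in this measurement.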

Compound 3, percent growth inhibition at one concentration: 68%
The estimate for compound 3 lay 2 percentage points above the measured number, within the range that was stated.
By their numbers in this assay, from the lowest: compounds 1, 3 and 2 (each within the scatter of the next).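

Turning phenoxy into 4-bromophenoxy gives a number 1 percentage points lower from compound 2 to compound 3 (within the scatter) in this assay, so this position takes a bromine atom with no shift beyond the usual scatter. Setting 4-bromophenyl in place of methyl on the oxygen gives a number 3 percentage points higher from compound 1 to compound 3 (within the scatter), so this group also stays level with the methyl of compound 1. No supporting measurement offers an explanation for these results.

As far as these compounds go, whether an amine or a carboxylic acid in place of bromo would also leave the number level remains open. So does whether a longer chain in place of the 4-bromophenyl group on that oxygen would do so.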